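Shortening the ethyl to methyl on compound 3

This account rests on a few compounds, and the source may have more. Where it says the series, first, only, none or still open, it means among the compounds named here.

Of the compounds shown here, three sharing one core have been measured in a functional assay on the whole organism (strain albino) with Mus musculus as the target, at a dose of 100 mg/kg by the intraperitoneal route; on this read-out higher numbers stand for more inhibition at the one dose given (going by the name of the read-out) and lower numbers for less inhibition. Compound 1 `CCc1nc2ccccc2c(=O)n1NC(=O)Nc1ccc([N+](=O)[O-])cc1` gives 41%, compound 2 `Cc1ccc(NC(=O)Nn2c(-c3ccccc3)nc3ccccc3c2=O)cc1` gives 54%, and compound 3 `CCc1ccc(NC(=O)Nn2c(CC)nc3ccccc3c2=O)cc1` gives 58%. Compound 3 thus holds the highest of the three numbers, though compound 2 sits within the scatter of it, and only compound 1 lies clearly apart: a number 17 percentage points higher from compound 1 to compound 3 (beyond the scatter).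

Compound 4 `CCc1nc2ccccc2c(=O)n1NC(=O)Nc1ccc(C)cc1` differs from compound 3 in one place, (hydrogen in place of methyl on a saturated chain carbon bound to an aromatic carbon), that is, 4-ethylphenyl becomes 4-methylphenyl. For the measured compounds named here, no measured step covers this change directly. Going by the values given here, the only step in hand, the one from compound 1 to compound 3, swaps a nitro for an ethyl and is modest in size, whereas shortening ethyl to methyl is a far smaller alteration. Compound 2, which carries a methyl on the same aryl but a phenyl on the core, gives a number within the scatter of compound 3. In this assay, compound 4 is therefore expected to move little, a number 5 percentage points lower from compound 3 to compound 4 (within the scatter), and its estimated value is 53%, between 40% and 66%.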

Compound 4, a percentage reported as inhibition, in the whole organism at one dose (the size of the read-out at that dose, not a potency): 55%
Beside the measured number, compound 4's estimate is 2 percentage points below it, within the range that was stated.
By their numbers in this assay, from the lowest: compound 1; then compounds 2, 4 and 3 (each within the scatter of the next).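

In this assay, the change from 4-ethylphenyl to 4-methylphenyl gives a number 3 percentage points lower from compound 3 to compound 4 (within the scatter), so removing this methyl from the saturated chain carbon leaves no effect that can be told from the scatter. With 4-methylphenyl held fixed, putting ethyl in place of phenyl on the aromatic carbon of the core gives a number 1 percentage points higher from compound 2 to compound 4 (within the scatter), which adds a second pair in which the change has no effect beyond the scatter, while methyl in place of nitro gives a number 14 percentage points higher from compound 1 to compound 4 (beyond the scatter), so nitro stands apart from methyl as it does from ethyl. Nothing available gives a reason for any of these steps.

As far as these compounds go, it remains open whether a propyl chain, a butyl chain, an amine or a carboxylic acid in place of this alkyl group would stay level with methyl and ethyl or fall towards nitro. From the compounds shown here alone, how a benzyl group on the core would compare with ethyl and phenyl also remains open.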